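A few compounds are considered here, and "the series" means these few. Any claim that something is new, unique, unknown or untested is made for them only; others in the source may bear on it.

Four compounds that share one core are compared in an assay for displacement of a labelled ligand from Sigma non-opioid intracellular receptor 1 (Cavia porcellus), read by scintillation counting, with a stated time of 180 min; a lower number here means a stronger inhibitor, a higher number a weaker inhibitor. Compound 1 `CN(Cc1ccccc1)C(=O)CN1CCc2cc(OCc3ccccc3)ccc2C(O)C1` carries a benzyl group on an oxygen on an aromatic ring. In this assay compound 1 gives only a limit, > 1000 nM. Compound 2 `O=C(c1ccccc1)N1CCC(N2CCc3cc(OCc4ccccc4)ccc3C(O)C2)CC1` carries the same benzyl group but differs from compound 1 in a larger part of the molecule; how the two cores differ is not broken down here. In this assay compound 2 likewise gives only a limit, > 1000 nM. Compound 3 `CN(Cc1ccccc1)C(=O)CN1CCc2cc(O)ccc2C(O)C1` is compound 1 after one change, (hydrogen in place of benzyl on an oxygen on an aromatic ring). In this assay compound 3 gives 172 nM. That single change made an at least 5.8-fold lower number from compound 1 to compound 3 (0.76 log units; beyond the scatter).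

Compound 4 `O=C(c1ccccc1)N1CCC(N2CCc3cc(O)ccc3C(O)C2)CC1` is the not yet measured partner of compound 2 and carries the same change, (hydrogen in place of benzyl on an oxygen on an aromatic ring), with the same surroundings around the place where it is made. Compound 4 is expected to give 300 nM, with a likely range from 80 nM to 1500 nM. Within the data shown here, that expectation rests on an at least 5.8-fold lower number from compound 1 to compound 3 (0.76 log units; beyond the scatter), the one measured example of this change. The step is expected to be an at least 3.3-fold lower number from compound 2 to compound 4 (0.52 log units; beyond the scatter), though its size is uncertain because the limit of > 1000 nM in this assay, at which 2 of the 3 values shown sit, means the starting point for compound 2 is not a number.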

Compound 4, inhibition constant: > 1000 nM
Compound 4: no number, only a limit; the forecaster's own chance of this, stated with the estimate: 25%; at least 3.3-fold (0.52 log units) between middle value and limit.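

In this assay compound 4 gives > 1000 nM, which is a limit and not a number. No step from compound 2 to compound 4 can be read, because both compounds stop at the same limit: the limit of > 1000 nM in this assay, at which 3 of the 4 values shown sit.

The compounds shown leave open whether going from benzyloxy to hydroxy changes the binding of compound 2 at all, and by how much.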